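Removing the Acetyl Ester from a Piperidine Urea Antagonist

A few compounds are considered here, and "the series" means these few. Any claim that something is new, unique, unknown or untested is made for them only; others in the source may bear on it.

Compound 3 `CC(=O)OCC(C)(C)NC(=O)N(CCC1CCN(Cc2ccc(C)cc2)CC1)Cc1ccc(-c2ccccc2)cc1` gives the lowest of the three numbers in an in vitro functional assay on HEK293 cells for antagonist activity at melanin-concentrating hormone receptor 1 (Homo sapiens), read by GTPgammaS binding, with a stated time of 45 min (a lower number here means a stronger inhibitor, a higher number a weaker inhibitor), with 366 nM. Its nearest neighbour, compound 2 `COc1ccc(-c2ccc(CN(CCC3CCN(Cc4ccc(C)cc4)CC3)C(=O)NC(C)(C)COC(C)=O)cc2)cc1`, gives 647 nM; the step of a 1.8-fold lower number from compound 2 to compound 3 (0.25 log units; within the scatter) stays within the scatter. Compound 1 `Cc1ccc(CN2CCC(NC(=O)N(CC(=O)C(C)(C)O)Cc3ccc(-c4ccc(F)cc4)cc3)CC2)cc1`, which carries a different linker and a tertiary alcohol, gives 4530 nM.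

Compound 4 `Cc1ccc(CN2CCC(CCN(Cc3ccc(-c4ccccc4)cc3)C(=O)NC(C)(C)CO)CC2)cc1` differs from compound 3 by hydrogen in place of acetyl on an oxygen on a saturated carbon. No measured step covers this change: the single step shown concerns a methoxy on an aromatic carbon, and compound 1 differs from compound 3 in more than one place. With nothing to argue for a shift in either direction, the step of a 1.1-fold higher number from compound 3 to compound 4 (0.04 log units; within the scatter) is expected to stay within the scatter. Compound 4 is therefore estimated at 400 nM, in a range from 120 nM to 1300 nM.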

Compound 4, antagonist equilibrium constant: 122 nM
Compound 4: the middle estimate sits 3.3-fold (0.52 log units) above what was measured, within the range that was stated.
By their numbers in this assay, from the lowest: compound 4; then compounds 3 and 2 (each within the scatter of the next); then compound 1.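

For the compounds shown here, replacing acetoxymethyl with hydroxymethyl gives a 3.0-fold lower number from compound 3 to compound 4 (0.48 log units; beyond the scatter) in this assay and is the only step read at this oxygen; the one earlier step concerned an aromatic carbon and stayed within the scatter. The acetyl is thus not required here for the lower number, and the free hydroxy is tolerated. No evidence at hand accounts for the shift. From the compounds shown here alone, whether a methoxy, an amine or a carboxylic acid in place of this hydroxy would lower or raise the number stays open. So does the effect of a longer chain carrying the hydroxy.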